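A benzyl to cyclopropylmethyl swap with only a limit

A few compounds are considered here, and "the series" means these few. Any claim that something is new, unique, unknown or untested is made for them only; others in the source may bear on it.

In a physicochemical assay for permeability, using PAMPA (on this read-out higher numbers stand for higher permeability and lower numbers for lower permeability), compound 1 `COCCOc1cc2oc(=O)n(CCC(=O)O)c2cc1Cl` gives < 3 nm/s as a limit of the assay and not a number. Compound 2 `O=C(O)CCn1c(=O)oc2cc(OCc3ccccc3)c(Cl)cc21` comes out as "not determined" (no result reported) in this assay and so has no place on the scale. Compound 3 `O=C(O)CCn1c(=O)oc2cc(OCC3CC3)c(Cl)cc21` has not yet been measured. The change cyclopropyl in place of phenyl on a saturated chain carbon bound to an oxygen on an aromatic ring puts cyclopropyl in place of phenyl on a saturated chain carbon bound to an oxygen on an aromatic ring, turning benzyloxy into cyclopropylmethoxy. For the measured compounds named here, no measured step shows what such a change does. Going by the values given here, the only guide is the limit of < 3 nm/s in this assay, at which 1 of the 2 values shown sits, and compound 1 shares the core of compound 3, so a reading near that limit is expected, with no step beyond the usual scatter in either direction. For compound 3 the estimated value in this assay is 3 nm/s with an expected range from 1 nm/s to 12 nm/s and a fair chance of only a limit.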

Compound 3, apparent permeability: 19 nm/s
Estimate against measurement, compound 3: 6.3-fold (0.80 log units) below; measured number outside the range, above it.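

In this assay compound 3 gives 19 nm/s, the first reading among these compounds that is a number and not a limit, so this position on the shared core can carry a group with a measurable read-out. Putting cyclopropyl in place of methoxymethyl on a saturated chain carbon bound to an oxygen on an aromatic ring gives an at least 6.3-fold higher number from compound 1 to compound 3 (0.80 log units; beyond the scatter). That size is only a lower bound, since compound 1 stands at a limit of the assay: the limit of < 3 nm/s in this assay, at which 1 of the 3 values shown sits.

As far as these compounds go, compound 2 carries no number, so the step from benzyl to cyclopropylmethyl cannot be read, and the order of phenyl and cyclopropyl at this place stays open. Also open, from the compounds shown here alone, is how an amine or a longer chain in the same place would read in this assay.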